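Methyl replaced by (isopropylcarbonyl)oxy: compound 2 to compound 4

The compounds below may be only part of what the source reports. "The series", "measured", "known", "first", "only" and "open" are said of these compounds alone.

Measured so far in a functional assay on A549 cells (Homo sapiens) for cytotoxicity, with a stated time of 48 h; a higher number here means a weaker inhibitor, a lower number a stronger inhibitor:
- Compound 1 `COc1cccc2c(=O)cc(/C=C/[S+](C)[O-])oc12` gives 2200 nM.
- Compound 2 `Cc1ccc2oc(/C=C/[S+](C)[O-])cc(=O)c2c1` gives 1700 nM.
- Compound 3 `C[S+]([O-])/C=C/c1cc(=O)c2cc(C#N)ccc2o1` returns no number but only > 10000 nM, which is the limit of > 10000 nM in this assay, at which 1 of the 3 values shown sits.

Compound 2 holds the lowest of the two numbers, and compound 1 sits within the scatter of it; compound 3 contributes a limit only. Compound 4 `CC(C)C(=O)Oc1ccc2oc(/C=C/[S+](C)[O-])cc(=O)c2c1` differs from compound 2 in one place: (isopropylcarbonyl)oxy in place of methyl on an aromatic carbon. Within the data shown here, the only measured step that leaves from compound 2 is an at least 5.8-fold higher number from compound 2 to compound 3 (0.76 log units; beyond the scatter); it shows that exchanging the methyl on that aromatic carbon can weaken inhibition, yet a (isopropylcarbonyl)oxy group appears nowhere else, so that step cannot simply be carried over. A change no larger than modest is therefore expected in this assay, with weakening somewhat more likely than gain, namely a 2.1-fold higher number from compound 2 to compound 4 (0.31 log units; beyond the scatter). Compound 4 is estimated at 3500 nM, within a range from 1200 nM to 12000 nM, allowing some chance that this assay again reports only a limit.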

Compound 4, half-maximal inhibitory concentration: 2400 nM
For compound 4 the middle estimate is 1.5-fold (0.16 log units) above the measured one; the measured number falls inside the stated range.
By their numbers in this assay, from the lowest: compounds 2, 1 and 4 (each within the scatter of the next). At a limit, above all of these: compound 3.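

In this assay, methyl on this aromatic carbon can give way to the much larger (isopropylcarbonyl)oxy with no change beyond the scatter: a 1.4-fold higher number from compound 2 to compound 4 (0.15 log units; within the scatter). Exchange at this position therefore does not always weaken inhibition, as the nitrile of compound 3 alone might have suggested, and the two entering groups stand clearly apart: an at least 4.1-fold lower number from compound 3 to compound 4 (0.61 log units; beyond the scatter). The entry for compound 3 is a limit and not a number, so this step has only a bound: the limit of > 10000 nM in this assay, at which 1 of the 4 values shown sits.

Open, from the compounds shown here alone, is whether the same tolerance holds for other groups on this carbon, such as a hydroxyl, an amine, a carboxylic acid or a longer alkyl chain. Two exchanges at one position cannot show which difference between nitrile and (isopropylcarbonyl)oxy matters here.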